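A few compounds are considered here, and "the series" means these few. Any claim that something is new, unique, unknown or untested is made for them only; others in the source may bear on it.

Compound 1 `CC(C)N1C(=O)COc2ccc(-c3cccc(NS(=O)(=O)c4ccc(F)cc4)c3)cc21`: > 40000 nM, a limit
Compound 2 `O=C1COc2ccc(-c3cccc(NS(=O)(=O)c4ccc(F)cc4)c3)cc2N1C1CC1`: > 40000 nM, a limit
Compound 3 `COc1ccc(N2C(=O)COc3ccc(-c4cccc(NS(=O)(=O)c5ccc(F)cc5)c4)cc32)cc1`: 38500 nM

In a functional assay on A-375 cells (Homo sapiens) for antiproliferative activity, read by MTT assay, with a stated time of 72 h (on this read-out lower numbers stand for stronger inhibition and higher numbers for weaker inhibition), these three compounds differ only in the group on an amide-type nitrogen in a ring. Among the compounds with values here, compound 3 gives 38500 nM, the only actual number among them. The other two results are limits, and the series therefore rests largely on (the limit of > 40000 nM in this assay, at which 2 of the 3 values shown sit).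

Compound 4 `O=C1COc2ccc(-c3cccc(NS(=O)(=O)c4ccc(F)cc4)c3)cc2N1C1CCCCC1` has cyclohexyl in place of 4-methoxyphenyl on that nitrogen: cyclohexyl in place of 4-methoxyphenyl on an amide-type nitrogen in a ring. The closest evidence comes from the two steps that bring in 4-methoxyphenyl, an at least 1.0-fold lower number from compound 1 to compound 3 (0.01 log units; that floor lies within the scatter) and an at least 1.0-fold lower number from compound 2 to compound 3 (0.01 log units; that floor lies within the scatter). Both are floors within the scatter, so neither shows a measurable contribution from that group. The step that the two limits leave unreadable from compound 1 to compound 2 cannot be read at all. Removing 4-methoxyphenyl is therefore not expected to produce a change beyond the scatter, and the estimated step is a 1.0-fold higher number from compound 3 to compound 4 (0.02 log units; within the scatter). For compound 4 the estimated value is 40000 nM, with an expected range of 20000 nM to 70000 nM. A report as a limit alone is also considered likely.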

Compound 4, half-maximal inhibitory concentration: 23800 nM
Beside the measured number, compound 4's estimate is 1.7-fold (0.23 log units) above it, within the range that was stated.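

In this assay, cyclohexyl on the amide-type nitrogen in a ring gives a 1.6-fold lower number from compound 3 to compound 4 (0.21 log units; within the scatter), so exchanging the aromatic ring of 4-methoxyphenyl for a non-aromatic ring of carbon only, which also removes the one hydrogen-bond acceptor, does not move the result beyond the scatter. Within the data shown here, this is the first fully readable step at this position, as both of its values are actual numbers. The other two comparisons, an at least 1.6-fold lower number from compound 2 to compound 4 (0.22 log units; that floor lies within the scatter) and an at least 1.6-fold lower number from compound 1 to compound 4 (0.22 log units; that floor lies within the scatter), set cyclohexyl against cyclopropyl and isopropyl, and they remain floors because each starts from a limit: the limit of > 40000 nM in this assay, at which 2 of the 4 values shown sit.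

Going by these compounds, it remains open whether an amine or a carboxylic acid on this nitrogen would shift the number in this assay beyond the scatter. On these data alone, it is also open whether any change at this position, with the shared core kept, can do so.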